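The source may hold more compounds than are shown below. What is called first, only, known or untested is meant among the compounds shown, and "the series" means these compounds.

Notes on the series: compound 1 `CC(C)=CCC[C@]1(C)/C=C/[C@@H](OC(=O)C=C(C)C)[C@](C)(O)/C=C/C(=O)/C(C(=O)O)=C\C1` gives > 10000 nM in a functional assay on SMMC-7721 cells (Homo sapiens) for antiproliferative activity, read by MTT assay, with a stated time of 48 h (a lower number here means a stronger inhibitor, a higher number a weaker inhibitor), and this value is a limit, not a number. Going by the values given here, compound 2 `CO/N=C/C1=C/C[C@](C)(CCC=C(C)C)/C=C/[C@@H](OC(=O)C=C(C)C)[C@](C)(O)/C=C/C1=O` gives 3470 nM, the only actual number so far. Compound 3 `CC(C)=CCC[C@]1(C)/C=C/[C@@H](OC(=O)C=C(C)C)[C@](C)(O)/C=C/C(=O)/C(C(=O)N(C)C)=C\C1` has not been measured. It differs from compound 2 at one place, on the same double-bonded ring carbon: a group of 5 heavy atoms (3 carbon, 1 nitrogen, 1 oxygen; no ring) in place of a group of 4 heavy atoms (2 carbon, 1 nitrogen, 1 oxygen; no ring), on a double-bonded ring carbon, with dimethylcarbamoyl as the entering group. Among the compounds with values here, one measured step bears on this position, an at least 2.8-fold lower number from compound 1 to compound 2 (0.45 log units; beyond the scatter), and the limit of > 10000 nM in this assay, at which 1 of the 2 values shown sits, leaves its full size open. That step does not compare the two groups now in question, so its size cannot be carried over. No step beyond the scatter is therefore expected in this assay, with a slight drift to a higher number at most. The expected step is a 1.4-fold higher number from compound 2 to compound 3 (0.16 log units; within the scatter). For compound 3 the estimated value is 5000 nM, with an expected range of 2000 nM to 10000 nM.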

Compound 3, half-maximal inhibitory concentration: 3670 nM
For compound 3 the middle estimate is 1.4-fold (0.13 log units) above the measured one, and the stated range covers the measured number.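

In this assay, the dimethylcarbamoyl group on this double-bonded ring carbon does not separate from the group it replaces (a 1.1-fold higher number from compound 2 to compound 3 (0.02 log units; within the scatter)). Dimethylamino in place of hydroxy on the carbonyl carbon also gives a step beyond the scatter (an at least 2.7-fold lower number from compound 1 to compound 3 (0.43 log units; beyond the scatter)), so two different replacements of the carboxylic acid of compound 1 now stand within the scatter of each other. As far as these compounds go, the full size of that second step stays open because the value of compound 1 is a limit, not a number: the limit of > 10000 nM in this assay, at which 1 of the 3 values shown sits.

From the compounds shown here alone, whether a primary amide or a methyl ester on the same ring carbon stays in this range remains open. So does whether a longer chain on the amide nitrogen, or a morpholine amide, moves the number beyond the scatter from compound 2 and compound 3.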